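Swapping chloro for trifluoromethyl on a piperazine-linked aryl ring

The compounds below may be only part of what the source reports. "The series", "measured", "known", "first", "only" and "open" are said of these compounds alone.

Measured so far:
- compound 1, `CC(C(=O)N1CCN(c2ccccc2C(F)(F)F)CC1)N1C(=O)CCC1=O`: 50%
- compound 2, `CC(C(=O)N1CCN(c2cccc(Cl)c2)CC1)N1C(=O)CCC1=O`: 75%

Both compounds were tested in a functional assay on the whole organism (strain Swiss) with Mus musculus as the target, with a stated time of 2 h, at a dose of 300 mg/kg; a lower number here means a weaker effect, a higher number a stronger effect of the compound at the dose given. Compound 1, whose aromatic ring carries a trifluoromethyl group, gives 50%. Compound 2, whose aromatic ring carries a chloro group, gives 75%. Of the two numbers, compound 2 holds the higher one, and its distance from compound 1 lies beyond the usual scatter of this kind of measurement.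

The next compound, compound 3, `CC(C(=O)N1CCN(c2cccc(C(F)(F)F)c2)CC1)N1C(=O)CCC1=O`, has not yet been measured. It keeps the shared core of compound 2 and differs from it in one place: trifluoromethyl in place of chloro on an aromatic carbon. The substituent sits on an aromatic carbon of a six-membered aromatic ring of carbon only, meta to a large group.

For the measured compounds named here, no pair of measured compounds shows this exact exchange, so the size of the step is uncertain. Going by the values given here, the only trifluoromethyl-bearing compound measured, compound 1, gives 50%, a weaker effect than compound 2, but its group sits elsewhere on the ring. A modest downward step is expected, a number 15 percentage points lower from compound 2 to compound 3 (beyond the scatter), possibly within the scatter. Compound 3 is therefore estimated at 60%, with a range from 35% to 85%.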

Compound 3, a percentage reported as activity, at one dose (the size of the read-out at that dose, not a potency): 100%
Compound 3: middle estimate off by 40 percentage points, on the low side; measured number above the stated range.
By their numbers in this assay, from the lowest: compound 1; then compound 2; then compound 3.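

In this assay, trifluoromethyl in place of chloro on an aromatic carbon, meta to a large group, gives a number 25 percentage points higher from compound 2 to compound 3 (beyond the scatter), so a group of 4 heavy atoms in place of a single chlorine atom goes with a stronger effect at this place. Trifluoromethyl therefore does not by itself bring the lower number seen earlier: compound 1 carries the same group at another place on the ring and gives 50%, whereas compound 3 gives 100%, which suggests that the location of the group on the ring matters as well as its identity. Nothing available explains why the exchange raises the number.

These compounds leave open whether the gain belongs to trifluoromethyl in particular or would also appear with another group at the same place, such as a methoxy group, a bromine atom, a nitrile or an amine. Since each number is the size of the effect at a single dose and time, they also leave open how compound 2 and compound 3 would compare at lower doses or at other times.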